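The source may hold more compounds than are shown below. What is called first, only, known or untested is meant among the compounds shown, and "the series" means these compounds.

Measured so far in a functional assay on MCF7 cells (Homo sapiens) for inhibition, read by MTT assay, with a stated time of 48 h; on this read-out higher numbers stand for weaker inhibition of growth and lower numbers for stronger inhibition of growth
Compound 1 `COc1ccc2c(c1)c(C1CC(c3ccc(F)cc3)=NN1C(=O)c1ccc(OC)nc1)cn2C` gives 480 nM
Compound 2 `COc1ccc(C2=NN(C(=O)c3ccc(OC)nc3)C(c3cn(C)c4ccc(OC)cc34)C2)cc1` gives 560 nM
Compound 3 `COc1ccc2c(c1)c(C1CC(c3cc(OC)c(OC)c(OC)c3)=NN1C(=O)c1ccc(OC)nc1)cn2C` gives > 10000 nM

Compound 3 stands at > 10000 nM as a limit of the assay and not a number. Compound 4 `COc1cccc(C2=NN(C(=O)c3ccc(OC)nc3)C(c3cn(C)c4ccc(OC)cc34)C2)c1` differs from it by one change, (3-methoxyphenyl in place of 3,4,5-trimethoxyphenyl on a carbon with a double bond to nitrogen), with 3-methoxyphenyl in place of 3,4,5-trimethoxyphenyl on a carbon with a double bond to nitrogen.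

Two large steps bear on this: an at least 17-fold higher number from compound 2 to compound 3 (1.25 log units; beyond the scatter) when 3,4,5-trimethoxyphenyl replaces 4-methoxyphenyl, and an at least 20-fold higher number from compound 1 to compound 3 (1.31 log units; beyond the scatter) when it replaces 4-fluorophenyl. The third step, a 1.2-fold higher number from compound 1 to compound 2 (0.07 log units; within the scatter), lies within the scatter. Compound 2 carries 4-methoxyphenyl and gives 560 nM in this assay, so a single methoxy group at this place is compatible with a measurable value.

A large fall in the number, towards stronger inhibition of growth, is therefore expected, and the estimated step is an at least 11-fold lower number from compound 3 to compound 4 (1.04 log units; beyond the scatter) for this change. Compound 4 has an estimated value of 900 nM (expected range 300 nM to 4000 nM).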

Compound 4, concentration for 50% growth inhibition: 130 nM
Beside the measured number, compound 4's estimate is 6.9-fold (0.84 log units) above it; the measured number lies below the stated range.
By their numbers in this assay, from the lowest: compound 4; then compounds 1 and 2 (each within the scatter of the next). At a limit, above all of these: compound 3.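

Moving the single methoxy group matters at this place: 3-methoxyphenyl in place of 4-methoxyphenyl gives a 4.3-fold lower number from compound 2 to compound 4 (0.63 log units; beyond the scatter) and 3-methoxyphenyl in place of 4-fluorophenyl gives a 3.7-fold lower number from compound 1 to compound 4 (0.57 log units; beyond the scatter). Compound 1 and compound 2 lie within the scatter of each other. Removing two methoxy groups from 3,4,5-trimethoxyphenyl gives an at least 76-fold lower number from compound 3 to compound 4 (1.88 log units; beyond the scatter) and shows that a methoxy group at the 3-position of this phenyl is compatible with the lowest number here. Compound 3 stands at a limit and not a number, so this step is only a minimum: the limit of > 10000 nM in this assay, at which 1 of the 4 values shown sits.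

As far as these compounds go, whether 3-fluorophenyl would match 3-methoxyphenyl remains open. So does the effect of an amine, a carboxylic acid or a longer chain such as ethoxy at this place.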